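A Trifluoromethoxy for Fluoro Change on Compound 3

A few compounds are considered here, and "the series" means these few. Any claim that something is new, unique, unknown or untested is made for them only; others in the source may bear on it.

Of the compounds shown here, three have been measured in a functional assay on CWR22R cells (Homo sapiens) for antiproliferative activity, read by propidium iodide staining, with a stated time of 96 h (a higher number here means a weaker inhibitor, a lower number a stronger inhibitor), so far. Compound 1 (`CC(O)(COc1cccc(S(F)(F)(F)(F)F)c1)C(=O)Nc1ccc([N+](=O)[O-])cc1C(F)(F)F`) gives 15500 nM there, compound 2 (`CC(O)(COc1ccc(C#N)cc1)C(=O)Nc1cccc(S(F)(F)(F)(F)F)c1`) gives 32500 nM and compound 3 (`CC(O)(CS(=O)(=O)c1ccc(F)cc1)C(=O)Nc1cccc(S(F)(F)(F)(F)F)c1`) gives 38900 nM in the same read-out. Compound 3 sits within the scatter of compound 2, while compound 1 has a lower number than compound 3 by more than the scatter, and so is the stronger inhibitor of that pair.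

Compound 4 (`CC(O)(CS(=O)(=O)c1ccc(OC(F)(F)F)cc1)C(=O)Nc1cccc(S(F)(F)(F)(F)F)c1`) is compound 3 with trifluoromethoxy in place of fluoro on an aromatic carbon, para to a large group (trifluoromethoxy in place of fluoro on an aromatic carbon). Among the measured compounds shown here, no two measured compounds differ in only one place, so the data offer no direct guide to this change. Only a slight shift towards a lower number is expected in this assay, with no step beyond the scatter. The estimate means a 1.3-fold lower number from compound 3 to compound 4 (0.11 log units; within the scatter) as the expected step. For compound 4 the estimated value is 30000 nM in this assay (expected range 12000 nM to 70000 nM).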

Compound 4, half-maximal inhibitory concentration: 31200 nM
For compound 4 the middle estimate is 1.0-fold (0.02 log units) below the measured one; the measured number falls inside the stated range.
By their numbers in this assay, from the lowest: compounds 1, 4, 2 and 3 (each within the scatter of the next, the first and the last beyond it).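

In this assay, among the compounds shown here, the change from fluoro to trifluoromethoxy on an aromatic carbon, para to a large group, gives a 1.2-fold lower number from compound 3 to compound 4 (0.10 log units; within the scatter) as the first step in which two compounds differ in only one place. At this position, the 4-fluorophenyl and 4-(trifluoromethoxy)phenyl forms therefore cannot be told apart in this read-out, although the entering group has 5 heavy atoms where the leaving group has 1 and it adds 1 hydrogen-bond acceptor.

The compounds shown leave open whether an amine, a carboxylic acid or a longer alkyl chain at the same position would also stay within the scatter, and whether the same exchange would do so on another compound. No measurement shown here offers an explanation for this result.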